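The compounds below may be only part of what the source reports. "The series", "measured", "known", "first", "only" and "open" are said of these compounds alone.

Of the compounds shown here, three sharing one core have been tested in a functional assay on HT-22 cells (Mus musculus), read by MTT assay, with a stated time of 24 h; a lower number here means that less compound is needed, a higher number that more compound is needed for the effect. In this assay, compound 1 `COc1ccc(-c2cc(OC)c3ccccc3n2)cc1O` is reported as "not active" (no number reported), and compound 3 `COc1cc(-c2ccc(O)cc2)nc2ccccc12` is reported as "not active" (no number reported). Neither entry carries a number. Going by the values given here, compound 2 `COc1cc(-c2ccc(O)c(O)c2)nc2ccccc12` gives 40 nM, the only number in the set, so it has no measured value to be ranked against.

Compound 4 `CC(C)Oc1cc(-c2ccc(O)c(O)c2)nc2ccccc12` departs from compound 2 in one place: isopropyl in place of methyl on an oxygen on an aromatic ring. This is isopropyl in place of methyl on an oxygen on an aromatic ring, or methoxy to isopropoxy. Among the compounds with values here, no measured pair shows what such a change does in this assay, so the expectation starts from compound 2 at 40 nM and stays uncertain. A modest move towards more compound being needed is expected, possibly not beyond the usual scatter, and a loss of measurable activity cannot be ruled out. The estimated size of the change is a 1.8-fold higher number from compound 2 to compound 4 (0.24 log units; within the scatter). For compound 4 the expected value is 70 nM, with an estimated range from 15 nM to 350 nM.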

Compound 4, half-maximal effective concentration: 20 nM
For compound 4 the middle estimate is 3.5-fold (0.54 log units) above the measured one, and the stated range covers the measured number.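

In this assay, going from methoxy to isopropoxy gives a 2.0-fold lower number from compound 2 to compound 4 (0.30 log units; within the scatter), so the two compounds cannot be told apart. Going by these compounds alone, this is the first sign that the position on an oxygen on an aromatic ring accepts isopropyl in place of methyl without losing measurable activity, and the shared core now has two numbers rather than one. Nothing shown bears on the reason for this result.

The compounds shown leave open how far this tolerance extends, since only methyl and isopropyl appear on this oxygen, and a longer chain such as n-butyl, or a benzyl group, could behave differently. Going by these compounds, it also remains open whether a chain ending in an amine or a carboxylic acid would keep a measurable value at this position.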